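Working notes: amine replacement on the shared core

This account rests on a few compounds, and the source may have more. Where it says the series, first, only, none or still open, it means among the compounds named here.

Values in an assay on HEK293 cells for inhibition of Fatty-acid amide hydrolase 1 (Homo sapiens), read by fluorescence; a higher number here means a weaker inhibitor, a lower number a stronger inhibitor:
compound 1, `c1cc2cc(-c3ccc4oc(NC5CCCCC5)nc4c3)cnc2[nH]1`: > 1000 nM
compound 2, `CCn1ccc2cc(-c3ccc4oc(NC5CCCCC5)nc4c3)ccc21`: 207 nM
compound 3, `Cn1ccc2cc(-c3ccc4oc(Nc5ccc(F)cc5)nc4c3)ccc21`: 99 nM

The value for compound 1 is a limit of this assay and not a number (the limit of > 1000 nM in this assay, at which 1 of the 3 values shown sits). Among the two numbers, compound 3 gives the lowest, and compound 2 gives a number that is higher by more than the scatter. Among the compounds with values here, compounds 2 and 3 differ in more than one place, so no single step between them can be drawn, and the values are taken only as what they show.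

Compound 4, `C[C@@H]1CN(c2nc3cc(-c4ccc5c(ccn5C)c4)ccc3o2)C[C@H](C)O1`, is not yet measured in this assay. It differs from compound 3 in one place: 2,6-dimethylmorpholin-4-yl in place of (4-fluorophenyl)amino on an aromatic carbon. Within the data shown here, no measured step covers a change of this kind, so the expectation rests on the change itself and on the number for compound 3. The expected direction is toward a higher number, of moderate size, beyond the scatter but not by a large margin. The step of a 4.0-fold higher number from compound 3 to compound 4 (0.61 log units; beyond the scatter) is the expected size and direction. For compound 4 the expected value in this assay is 400 nM, with a range from 120 nM to 1500 nM.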

Compound 4, half-maximal inhibitory concentration: 168 nM
For compound 4 the middle estimate is 2.4-fold (0.38 log units) above the measured one; measured number inside the range.
By their numbers in this assay, from the lowest: compounds 3, 4 and 2 (each within the scatter of the next, the first and the last beyond it). At a limit, above all of these: compound 1.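

In this assay, putting 2,6-dimethylmorpholin-4-yl in place of (4-fluorophenyl)amino, on the aromatic carbon next to the ring nitrogen and next to the ring oxygen, gives a 1.7-fold higher number from compound 3 to compound 4 (0.23 log units; within the scatter), the only step in one place among the compounds shown and so the first reading of this position. The group that leaves has one six-membered aromatic ring of carbon only and 1 hydrogen-bond donor, while the group that enters has one six-membered non-aromatic ring with 2 hetero atoms and 0 hydrogen-bond donors. For this one pair, then, neither that aromatic ring nor that donor is needed for a value within the scatter of compound 3, though one pair sets no rule for the position.

Still open, on these data alone, is whether morpholin-4-yl without the two methyl groups, or piperidin-1-yl with a ring carbon in place of the ring oxygen, would stay within the scatter of compound 3 on the same carbon, and whether the two defined stereocentres of compound 4 matter. Nothing measured among these compounds gives a cause for this step.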